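A fluoro step on the benzyl group of compound 2

A few compounds are considered here, and "the series" means these few. Any claim that something is new, unique, unknown or untested is made for them only; others in the source may bear on it.

Compound 1 `C=CCOc1ccc2c(=O)c(-c3cc(OC)c(OC)cc3OC)coc2c1`: 5900 nM
Compound 2 `COc1cc(OC)c(-c2coc3cc(OCc4ccccc4)ccc3c2=O)cc1OC`: 6750 nM
Compound 3 `COc1cccc(C(=O)Oc2ccc3c(=O)c(-c4cc(OC)c(OC)cc4OC)coc3c2)c1`: > 10000 nM, a limit

In a functional assay on U-251 cells (Homo sapiens) for antiproliferative activity, read by MTT assay, with a stated time of 24 h (on this read-out higher numbers stand for weaker inhibition and lower numbers for stronger inhibition), compound 2 stands level with compound 1, a 1.1-fold higher number from compound 1 to compound 2 (0.06 log units; within the scatter). Compound 3 gives only a limit in this assay: the limit of > 10000 nM in this assay, at which 1 of the 3 values shown sits. Compound 4 `COc1cc(OC)c(-c2coc3cc(OCc4ccccc4F)ccc3c2=O)cc1OC` differs from compound 2 by fluoro in place of hydrogen on an aromatic carbon, with fluoro in place of hydrogen on an aromatic carbon, so that benzyl becomes 2-fluorobenzyl. Among the measured compounds shown here, no measured step makes this exact change. The closest one, from compound 1 to compound 2, stayed within the scatter, so no step beyond the scatter is expected in this assay. The expected step is a 1.1-fold lower number from compound 2 to compound 4 (0.05 log units; within the scatter). For compound 4 the estimated value is 6000 nM, with an expected range of 3000 nM to 10000 nM.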

Compound 4, half-maximal inhibitory concentration: 2890 nM
Compound 4: middle estimate off by 2.1-fold (0.32 log units), on the high side, and the stated range ends above it.
By their numbers in this assay, from the lowest: compound 4; then compounds 1 and 2 (each within the scatter of the next). At a limit, above all of these: compound 3.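

In this assay the move from allyl to benzyl stayed within the scatter, but one fluoro ortho to a large group on the benzyl ring does not: a 2.3-fold lower number from compound 2 to compound 4 (0.37 log units; beyond the scatter). The 2-fluorobenzyl group also stands apart from allyl, with a 2.0-fold lower number from compound 1 to compound 4 (0.31 log units; beyond the scatter), and from the (3-methoxyphenyl)carbonyl group of compound 3, which gives only a limit, with an at least 3.4-fold lower number from compound 3 to compound 4 (0.53 log units; beyond the scatter). Nothing shown here accounts for this step.

On these data alone, whether chloro or methoxy in this place would give a similar step remains open, as does the effect of fluoro elsewhere on this ring.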